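The compounds below may be only part of what the source reports. "The series", "measured", "known", "first", "only" and "open" are said of these compounds alone.

In an ADME assay on HT-29 cells (Homo sapiens) for cytotoxicity, read by MTT assay, with a stated time of 72 h (a lower number here means a stronger inhibitor, a higher number a weaker inhibitor), the three measured compounds stand as follows: compound 1 `C=CC(=O)Nc1cc(Nc2ncc3ncn(-c4ccc(C)cc4)c3n2)c(OC)cc1N(C)CCN(C)C` gives 9230 nM; compound 2 `C=CC(=O)Nc1cc(Nc2ncc3ncn(-c4ccc(C(C)C)cc4)c3n2)c(OC)cc1N(C)CCN(C)C` gives 15300 nM; compound 3 `C=CC(=O)Nc1cc(Nc2ncc3ncn(-c4ccc(Br)cc4)c3n2)c(OC)cc1N(C)CCN(C)C` gives 1460 nM.

Compound 3 holds the lowest number of the three: a 6.3-fold lower number from compound 1 to compound 3 (0.80 log units; beyond the scatter) and a 10-fold lower number from compound 2 to compound 3 (1.02 log units; beyond the scatter), while a 1.7-fold higher number from compound 1 to compound 2 (0.22 log units; within the scatter). Compound 4 `C=CC(=O)Nc1cc(Nc2ncc3ncn(-c4ccccc4Br)c3n2)c(OC)cc1N(C)CCN(C)C` differs from compound 3 by 2-bromophenyl in place of 4-bromophenyl on an aromatic nitrogen. Going by the values given here, none of the measured steps moves a group around the ring in this way; they only exchange one group for another at the same place, so they fix no size for this change. Because compound 3 gives 1460 nM with the bromine retained, the estimate for compound 4 in this assay is set near it, expected at 3500 nM within a wide range from 900 nM to 14000 nM. That estimate means an expected step of a 2.4-fold higher number from compound 3 to compound 4 (0.38 log units; beyond the scatter).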

Compound 4, half-maximal inhibitory concentration: 16200 nM
Beside the measured number, compound 4's estimate is 4.6-fold (0.67 log units) below it; the measured number lies above the stated range.
By their numbers in this assay, from the lowest: compound 3; then compounds 1, 2 and 4 (each within the scatter of the next).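

In this assay, the move from 4-bromophenyl to 2-bromophenyl on the aromatic nitrogen gives an 11-fold higher number from compound 3 to compound 4 (1.05 log units; beyond the scatter), so with the same atoms joined differently, keeping the bromine does not keep the low number of compound 3. The other two steps are a 1.1-fold higher number from compound 2 to compound 4 (0.02 log units; within the scatter) and a 1.8-fold higher number from compound 1 to compound 4 (0.24 log units; within the scatter), which leave compound 4 level with both. Nothing measured here gives a reason for the large step.

The compounds shown leave open whether a methoxy or an amino group, in the place the bromine holds in 2-bromophenyl, would give a similar number.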